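This account rests on a few compounds, and the source may have more. Where it says the series, first, only, none or still open, it means among the compounds named here.

Compound 3 `CCCc1nc(C)c2cnnc(SC)n12` stands at the edge of what a functional assay for inhibition, with Homo sapiens as the target (on this read-out lower numbers stand for stronger inhibition and higher numbers for weaker inhibition), can report: compound 3 gives > 48000 nM, which is a limit of the assay and not a number. Compound 1 `CCCc1nc(C)c2cnnc(O)n12` gives 56800 nM in this assay. Compound 2 `CCc1nc(C)c2cnnc(SC)n12` also returns a limit in this assay, namely > 48000 nM. Compound 4 `CCCc1nc(C)c2cnnc(NCCN(C)C)n12` differs from compound 3 by (2-(dimethylamino)ethyl)amino in place of methylsulfanyl on an aromatic carbon. The two measured steps that end at compound 3, a step that the limit leaves unreadable from compound 1 to compound 3 and a step that the two limits leave unreadable from compound 2 to compound 3, are both unreadable, as the limit of > 48000 nM in this assay, at which 2 of the 3 values shown sit, sets out. Within the data shown here, no measured step touches the group that enters in compound 4. The expected step is an at least 1.6-fold lower number from compound 3 to compound 4 (0.20 log units; that floor lies within the scatter) in this assay, with nothing measured to anchor its size or direction. Compound 4 is estimated at 30000 nM, between 5000 nM and 100000 nM.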

Compound 4, half-maximal inhibitory concentration: > 48000 nM
Compound 4: only a limit was reported (the forecaster's own chance of this, stated with the estimate: 45%); at least 1.6-fold (0.20 log units) between middle value and limit.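

Compound 4 returns only a limit in this assay, so no step from compound 3 or compound 1 to it can be read: the limit of > 48000 nM in this assay, at which 3 of the 4 values shown sit.

The compounds shown leave open whether any group on this aromatic carbon of the shared core gives a readable number under that limit.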